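Trading the Benzyl Piperidine for a Methoxy Piperidine

The source may hold more compounds than are shown below. What is called first, only, known or untested is meant among the compounds shown, and "the series" means these compounds.

Compound 1, `Cc1ccc(Nc2nc(C(F)(F)F)ccc2CNC(=O)C(C)c2ccc(NS(C)(=O)=O)c(F)c2)cc1C`, gives 39.3 nM in a functional assay on CHO-K1 cells for antagonist activity at transient receptor potential cation channel subfamily V member 1 (Homo sapiens), read by FLIPR; a lower number here means a stronger inhibitor, a higher number a weaker inhibitor.
Compound 2, `CC(C(=O)NCc1ccc(C(F)(F)F)nc1N(C)c1ccccc1)c1ccc(NS(C)(=O)=O)c(F)c1`, gives 0.9 nM.
Compound 3, `CC(C(=O)NCc1ccc(C(F)(F)F)nc1N1CCC(Cc2ccc(F)c(F)c2)CC1)c1ccc(NS(C)(=O)=O)c(F)c1`, gives 0.2 nM.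

Compound 3 stands at the lowest number of the three; compound 2 is nearest to it and compound 1 furthest, both gaps beyond the scatter. Compound 4, `COC1CCN(c2nc(C(F)(F)F)ccc2CNC(=O)C(C)c2ccc(NS(C)(=O)=O)c(F)c2)CC1`, differs from compound 3 in a single place: methoxy in place of 3,4-difluorobenzyl on a saturated ring carbon. Among the measured compounds shown here, only one measured step exists, a 44-fold lower number from compound 1 to compound 2 (1.64 log units; beyond the scatter), and it concerns the group on the aromatic carbon of the shared core rather than a saturated ring carbon, so it touches the new change only indirectly; still, it shows that alterations in that part of the molecule can move the number a great deal. Compound 2 and compound 3 together show that the two amines so far carrying an aromatic ring both sit at low numbers. Removing that ring in compound 4 is expected to raise the number, a 25-fold higher number from compound 3 to compound 4 (1.40 log units; beyond the scatter), with wide uncertainty. Compound 4 is therefore estimated at 5 nM, between 1 nM and 30 nM.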

Compound 4, inhibition constant: 2.4 nM
The estimate for compound 4 lay 2.1-fold (0.32 log units) above the measured number; low and high end bracket the measured number.
By their numbers in this assay, from the lowest: compound 3; then compound 2; then compound 4; then compound 1.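

In this assay the 3,4-difluorobenzyl group on the saturated ring carbon proves helpful but not essential: replacing it with methoxy, which has no ring, gives a 12-fold higher number from compound 3 to compound 4 (1.08 log units; beyond the scatter) and still leaves compound 4 at 2.4 nM in the low range of this set. On the aromatic carbon of the shared core, 4-methoxypiperidin-1-yl gives a 2.7-fold higher number from compound 2 to compound 4 (0.43 log units; beyond the scatter) against methyl(phenyl)amino and a 16-fold lower number from compound 1 to compound 4 (1.21 log units; beyond the scatter) against (3,4-dimethylphenyl)amino, so a group with no aromatic ring can still outdo one of the two anilines. Nothing available explains these differences.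

The compounds shown leave open whether the rise from compound 3 follows the loss of the aromatic ring or of its two fluorine atoms. They also leave open how a plain benzyl or a hydroxy group on that saturated ring carbon would read.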